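Chain homologation of the aminoacyl side chain

The source may report more compounds than this note shows. Statements on the series, on what has been measured and on what is new or still open speak of the compounds shown alone.

Compound 1 `COc1ccc(S(=O)(=O)N2C[C@H](NC(=O)CCCN)C[C@@H]2C(=O)NO)cc1` gives 53 nM in an assay on isolated protein for inhibition of matrix metalloproteinase-9 (Homo sapiens), read by fluorescence; on this read-out higher numbers stand for weaker inhibition and lower numbers for stronger inhibition. Compound 2 `COc1ccc(S(=O)(=O)N2C[C@H](NC(=O)[C@@H](N)CCCN)C[C@@H]2C(=O)NO)cc1` gives 154 nM in this assay and so carries the highest of the two numbers measured; its nearest neighbour is compound 1, and the change from it reads a 2.9-fold higher number from compound 1 to compound 2 (0.46 log units; beyond the scatter). Compound 3 `COc1ccc(S(=O)(=O)N2C[C@H](NC(=O)[C@@H](N)CCCCN)C[C@@H]2C(=O)NO)cc1` is not yet measured in this assay. Its difference from compound 2 is aminomethyl in place of amino on a saturated chain carbon, four bonds along the chain from an amine nitrogen and a carbonyl carbon. Within the data shown here, only the step from compound 1 to compound 2 bears on this, and it reworked the side chain differently rather than lengthening it alone, so it offers no direct guide for a one-carbon homologation. In this assay compound 3 is therefore expected to show a 1.0-fold lower number from compound 2 to compound 3 (0.01 log units; within the scatter), no shift beyond the scatter, with an estimate of 150 nM in the range 60 nM to 400 nM.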

Compound 3, half-maximal inhibitory concentration: 5.7 nM
For compound 3 the middle estimate is 26-fold (1.42 log units) above the measured one, and the stated range ends above it.
By their numbers in this assay, from the lowest: compound 3; then compound 1; then compound 2.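

Working notes: in this assay, aminomethyl in place of amino on this saturated chain carbon gives a 27-fold lower number from compound 2 to compound 3 (1.43 log units; beyond the scatter), so the number at this position depends strongly on where the chain places its terminal amine. The weakening seen on going from compound 1 to compound 2 does not hold for the longer chain: the 1,5-diaminopentyl group in place of 3-aminopropyl gives a 9.3-fold lower number from compound 1 to compound 3 (0.97 log units; beyond the scatter), a shift in the opposite direction. No measurement in hand explains the size of this change.

Still open, on these data alone, is whether a longer chain ending in an amine lowers the number further or raises it again. Also open, as far as these compounds go, is whether a guanidine or a carboxylic acid at the chain end would keep compound 3's standing.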